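The source may hold more compounds than are shown below. What is called first, only, known or untested is meant among the compounds shown, and "the series" means these compounds.

The account begins with two measured compounds of one series. Compound 1 `O=C(O)C1(Sc2ccnc3cccnc23)CCC1` reaches only the limit of the assay, giving > 10000 nM in an assay on HEK293 cells for inhibition of solute carrier family 22 member 12 (Homo sapiens), read by scintillation counting, with a stated time of 12 min (on this read-out lower numbers stand for stronger inhibition and higher numbers for weaker inhibition), which is a limit and not a number. Compound 2 `Nc1ccc2nccc(SC3(C(=O)O)CCC3)c2c1` gives 1790 nM in this assay, and this is the only number shown in the set. The other value recorded, that of compound 1, is a limit, as noted under (the limit of > 10000 nM in this assay, at which 1 of the 2 values shown sits), so compound 2 cannot be placed against a second number.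

The step under study leads from compound 2 to compound 3 `O=C(O)C1(Sc2ccnc3ccc(O)cc23)CCC1`, which has not yet been measured. The change is hydroxy in place of amino on an aromatic carbon of the core shared by the two compounds. Among the measured compounds shown here, no measured pair in the set shows a change of this kind, so there is no step on which to lean. With only the number of compound 2 in hand, a step close to the scatter is expected, in no firm direction. For compound 3 the estimate is 1500 nM, between 400 nM and 6000 nM, which would mean an expected step of a 1.2-fold lower number from compound 2 to compound 3 (0.08 log units; within the scatter).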

Compound 3, half-maximal inhibitory concentration: > 10000 nM
Compound 3: only a limit was reported (the forecaster's own chance of this, stated with the estimate: 15%); middle value at least 6.6-fold (0.82 log units) from the limit.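

Putting hydroxy in place of amino on this aromatic carbon gives an at least 5.5-fold higher number from compound 2 to compound 3 (0.74 log units; beyond the scatter) in this assay. The position therefore does not treat the two groups alike, although they match in every count computed for them, and of the three compounds shown only compound 2, which carries the amino group, gives a number and not a limit. Compound 3 stands at a limit, so the step has only a least size and no full size: the limit of > 10000 nM in this assay, at which 2 of the 3 values shown sit.

On these data alone, how much weaker compound 3 may be stays open, as does what in the amino group the read-out depends on. A methylamino, dimethylamino, acetamide or methoxy group on the same aromatic carbon could begin to separate these questions, and the compounds shown do not say what any of them would give.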